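Diethylamino in place of propanoylamino: expected effect

The source may report more compounds than this note shows. Statements on the series, on what has been measured and on what is new or still open speak of the compounds shown alone.

compound 1 `C=CNCc1cc(-c2c(C(=O)NCC)noc2-c2cc(C(C)C)c(O)cc2O)on1` gives 121 nM in a functional assay on HCT-116 cells (Homo sapiens) for inhibition; a higher number here means a weaker inhibitor, a lower number a stronger inhibitor
compound 2 `CCNC(=O)c1noc(-c2cc(C(C)C)c(O)cc2O)c1-c1cc(CNC(C)=O)no1` gives 167 nM in this assay
compound 3 `CCNC(=O)c1noc(-c2cc(C(C)C)c(O)cc2O)c1-c1cc(CNC(=O)CC)no1` gives 78 nM in this assay

Compound 3 stands at the low end of these numbers, but only one of its two gaps is clear: a 2.1-fold lower number from compound 2 to compound 3 (0.33 log units; beyond the scatter) is a modest step beyond the scatter, while a 1.6-fold lower number from compound 1 to compound 3 (0.19 log units; within the scatter) stays within it. Next comes compound 4 `CCNC(=O)c1noc(-c2cc(C(C)C)c(O)cc2O)c1-c1cc(CN(CC)CC)no1`, which has diethylamino in place of propanoylamino on a saturated chain carbon bound to an aromatic carbon and has not yet been measured.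

Going by the values given here, no measured compound carries diethylamino, so the evidence is indirect. The nearest guide is the change on the same amine nitrogen, where a 1.4-fold higher number from compound 1 to compound 2 (0.14 log units; within the scatter) lies within the scatter. Changes at this site have so far stayed small, and a large step is not expected. The expected result is a 1.8-fold higher number from compound 3 to compound 4 (0.25 log units; within the scatter), a small rise whose direction remains uncertain. For compound 4 the estimate is 140 nM, with an expected range from 50 nM to 400 nM in this assay.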

Compound 4, half-maximal inhibitory concentration: 38 nM
Estimate against measurement, compound 4: 3.7-fold (0.57 log units) above; the whole stated range lies above it.
By their numbers in this assay, from the lowest: compound 4; then compounds 3, 1 and 2 (each within the scatter of the next, the first and the last beyond it).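

Going from propanoylamino to diethylamino gives a 2.1-fold lower number from compound 3 to compound 4 (0.31 log units; beyond the scatter) in this assay, so the group on this saturated chain carbon needs neither a carbonyl nor a hydrogen-bond donor to keep inhibition. The other two steps, a 4.4-fold lower number from compound 2 to compound 4 (0.64 log units; beyond the scatter) and a 3.2-fold lower number from compound 1 to compound 4 (0.50 log units; beyond the scatter), are also beyond the scatter, which makes compound 4 the strongest inhibitor of the four and gives this site its first clear separation from all other compounds shown. The data offer no measurement that accounts for this gain.

Still open, from the compounds shown here alone, is whether the gain is specific to the two ethyl groups or extends to dimethylamino, dipropylamino, or ring amines such as pyrrolidine and morpholine. Also open, going by these compounds, is how a monoethylamino group would compare, which would show whether the second ethyl group matters.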